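Swapping the Sulfur-Linked Heteroaryl on a Shared Core

The source may report more compounds than this note shows. Statements on the series, on what has been measured and on what is new or still open speak of the compounds shown alone.

Compound 1 `Cn1nnnc1SCC(=O)Nc1ccc(-c2nc(-c3ccccc3)c(-c3ccccc3)n2C)cc1`: 63.7%
Compound 2 `Cc1nnc(SCC(=O)Nc2ccc(-c3nc(-c4ccccc4)c(-c4ccccc4)n3C)cc2)s1`: 74.9%

Among the measured compounds shown here, in a functional assay on MCF7 cells (Homo sapiens) for cytotoxicity, read by MTT assay, with a stated time of 24 h, tested at 16 ug/mL (a lower number here means a weaker effect, a higher number a stronger effect of the compound at the concentration tested), compound 2 stands highest of the two numbers; the one measured step is a number 11.2 percentage points higher from compound 1 to compound 2 (beyond the scatter). Compound 3 `Cn1ccnc1SCC(=O)Nc1ccc(-c2nc(-c3ccccc3)c(-c3ccccc3)n2C)cc1` differs from compound 2 by 1-methyl-1H-imidazol-2-yl in place of 5-methyl-1,3,4-thiadiazol-2-yl on a sulfur. From the compounds shown here alone, that single step bears on it only loosely: it shows that exchanging the ring on the sulfur can move the read-out by a modest amount, and the direction for a new ring is unknown. A modest change is therefore expected, and compound 3 is estimated at 66% with a range of 52% to 80%. This estimate means an expected step of a number 8.9 percentage points lower from compound 2 to compound 3 (within the scatter).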

Compound 3, a percentage reported as activity, at one concentration (the size of the read-out at that concentration, not a potency): 32.4%
The estimate for compound 3 lay 33.6 percentage points above the measured number; the whole stated range lies above it.
By their numbers in this assay, from the lowest: compound 3; then compound 1; then compound 2.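

In this assay, the 1-methyl-1H-imidazol-2-yl ring on the sulfur gives a number 42.5 percentage points lower from compound 2 to compound 3 (beyond the scatter) and a number 31.3 percentage points lower from compound 1 to compound 3 (beyond the scatter). Unlike the earlier exchange, this shows that the position can tolerate some rings while losing much of the read-out with another, even though the entering ring has the same heavy-atom count as 5-methyl-1,3,4-thiadiazol-2-yl. Nothing available here explains the fall.

Still open, from the compounds shown here alone, is how an amine or a carboxylic acid on this ring would affect the read-out. A six-membered ring such as pyridine on the sulfur also remains untested in the compounds shown.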